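Removing the nitrile from compound 2

This account rests on a few compounds, and the source may have more. Where it says the series, first, only, none or still open, it means among the compounds named here.

Compound 2 `N#Cc1ccc(-c2cnc3[nH]cc(-c4nnc(-c5ccc(Cl)cc5)o4)c(=O)c3c2)cc1` gives 35.4% in a functional assay on HCT-116 cells (Homo sapiens) for positive allosteric modulation, read by MTT assay, with stated times of 24 h and 48 h, tested at 2.5 uM (on this read-out lower numbers stand for less inhibition of growth and higher numbers for more inhibition of growth at the one concentration tested), the highest of the three numbers, though compound 3 `CS(=O)(=O)c1ccc(-c2cnc3[nH]cc(-c4nnc(-c5cccnc5)o4)c(=O)c3c2)cc1` with 28.6% and compound 1 `N#Cc1ccc(-c2cnc3[nH]cc(-c4nnc(-c5ccc(F)cc5)o4)c(=O)c3c2)cc1` with 25.6% both lie within the scatter of it. Among the measured compounds shown here, the one step measured in a single place, a number 9.8 percentage points higher from compound 1 to compound 2 (within the scatter), concerns a different part of the molecule and says nothing about the nitrile. Compound 4 `O=c1c(-c2nnc(-c3ccc(Cl)cc3)o2)c[nH]c2ncc(-c3ccccc3)cc12` differs from compound 2 by hydrogen in place of cyano on an aromatic carbon. For the measured compounds named here, no measured compound lacks this group, so the data give no direct guide to its removal. Compound 4 is therefore expected to move by only a number 6.4 percentage points lower from compound 2 to compound 4 (within the scatter), a step within the scatter. Compound 4 is estimated at 29%, with a range from 12% to 46%.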

Compound 4, percent growth inhibition at one concentration: 29.8%
For compound 4 the middle estimate is 0.8 percentage points below the measured one; the range from low to high includes it.
By their numbers in this assay, from the lowest: compounds 1, 3, 4 and 2 (each within the scatter of the next).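

In this assay, the change from 4-cyanophenyl to phenyl gives a number 5.6 percentage points lower from compound 2 to compound 4 (within the scatter), the first direct reading of this position among the compounds shown. With the rest of compound 2 unchanged, the nitrile on this six-membered aromatic ring, para to a large group, is therefore not required for growth inhibition in the range seen here. Nothing measured here explains the step. On these data alone, whether an amine or a carboxylic acid at this position would move the number beyond the scatter remains open. So does whether the same change would give a similar step in compound 1.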